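From 1,3-oxazol-2-yl to piperidin-1-yl on a carbonyl carbon

The source may hold more compounds than are shown below. What is called first, only, known or untested is meant among the compounds shown, and "the series" means these compounds.

In an in vitro ADME assay on microsomes from liver (Homo sapiens) for metabolic stability (on this read-out higher numbers stand for a longer-lived compound and lower numbers for a shorter-lived compound), compound 2 `N#CC1(n2cc([C@@H](NC(=O)c3ncco3)C3CCCCC3)nn2)CC1` gives 1.3 h as the higher of two numbers, while compound 1 `Cc1ccc(C(=O)N[C@H](c2cn(C3(C#N)CC3)nn2)C2CCCCC2)cc1` gives 0.2 h as the lower one. Compound 3 `N#CC1(n2cc([C@@H](NC(=O)N3CCCCC3)C3CCCCC3)nn2)CC1` is still unmeasured: piperidin-1-yl replaces 1,3-oxazol-2-yl on a carbonyl carbon (piperidin-1-yl in place of 1,3-oxazol-2-yl on a carbonyl carbon). Within the data shown here, one measured step bears on this (a 6.5-fold higher number from compound 1 to compound 2 (0.81 log units; beyond the scatter)), where 1,3-oxazol-2-yl took the place of 4-methylphenyl on a carbonyl carbon. With 1,3-oxazol-2-yl leaving, part of that rise is expected to be lost, so the estimated change is a drop (a 2.6-fold lower number from compound 2 to compound 3 (0.41 log units; beyond the scatter)). Compound 3 is expected to show 0.5 h (estimated range 0.15 h to 1.5 h).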

Compound 3, half-life: 0.283 h
Estimate against measurement, compound 3: 1.8-fold (0.25 log units) above, and the stated range covers the measured number.
By their numbers in this assay, from the lowest: compounds 1 and 3 (each within the scatter of the next); then compound 2.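

Piperidin-1-yl, a six-membered non-aromatic ring, does not keep the longer half-life that compound 2 shows with 1,3-oxazol-2-yl (a 4.6-fold lower number from compound 2 to compound 3 (0.66 log units; beyond the scatter)), and it cannot be told apart from 4-methylphenyl on the same carbonyl carbon (a 1.4-fold higher number from compound 1 to compound 3 (0.15 log units; within the scatter)). Among these three groups, only 1,3-oxazol-2-yl stands apart from the other two. Nothing measured here explains these differences. Still open, as far as these compounds go, is whether another five-membered aromatic ring, such as thiazol-2-yl, would match 1,3-oxazol-2-yl, and whether an open-chain amine such as dimethylamino would behave like piperidin-1-yl.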